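Sulfonamide to oxadiazole on the aromatic carbon

This account rests on a few compounds, and the source may have more. Where it says the series, first, only, none or still open, it means among the compounds named here.

Two compounds of the series are measured. Compound 1 `CC(C)(C)c1ccc(NC(=O)c2ccc(-c3ncccc3F)cc2)cc1` gives 3 nM in a functional assay for antagonist activity at transient receptor potential cation channel subfamily V member 1 (Homo sapiens), read by FLIPR; on this read-out higher numbers stand for weaker inhibition and lower numbers for stronger inhibition; compound 2 `CC(C)(C)c1ccc(NC(=O)c2ccc(-c3ncccc3NS(=O)(=O)c3ccccc3)cc2)cc1` gives 91 nM in this assay, the highest of the two numbers, and the step of a 30-fold higher number from compound 1 to compound 2 (1.48 log units; beyond the scatter) is large. Compound 3 `CC(C)(C)c1ccc(NC(=O)c2ccc(-c3ncccc3-c3nnco3)cc2)cc1` is not yet measured and differs from compound 2 by 1,3,4-oxadiazol-2-yl in place of (phenylsulfonyl)amino on an aromatic carbon. Among the compounds with values here, no measured step covers this exchange; only the step from compound 1 to compound 2 bears on it, as the entering group is counted smaller than the leaving one. For compound 3 a moderate fall is therefore expected, a 3.6-fold lower number from compound 2 to compound 3 (0.56 log units; beyond the scatter), with the estimate at 25 nM, from 6 nM to 100 nM.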

Compound 3, half-maximal inhibitory concentration: 91 nM
Beside the measured number, compound 3's estimate is 3.6-fold (0.56 log units) below it; low and high end bracket the measured number.
By their numbers in this assay, from the lowest: compound 1; then compounds 2 and 3 (each within the scatter of the next).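

In this assay, 1,3,4-oxadiazol-2-yl in place of (phenylsulfonyl)amino on this aromatic carbon gives no change at the digits printed from compound 2 to compound 3 (within the scatter), so removing heavy atoms and the hydrogen-bond donor leaves the number unmoved. Against fluoro, the same group gives a 30-fold higher number from compound 1 to compound 3 (1.48 log units; beyond the scatter), matching the earlier step to the sulfonamide, so two quite different groups read alike here. No measurement bears on the reason for this.

Open, from the compounds shown here alone, is whether a small group such as an amine, methoxy or chloro stays near compound 1 or falls in with compound 2 and compound 3. A carboxylic acid or a simple methyl at this carbon would test the same question.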